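Moving the trifluoromethyl group on the benzoyl ring

The compounds below may be only part of what the source reports. "The series", "measured", "known", "first", "only" and "open" are said of these compounds alone.

Three compounds share one core, a cyclic sulfonamide bearing a butyl ester side chain and an acyl group on the ring nitrogen. Compound 1 `CCCCOC(=O)CC1c2cccc(C)c2S(=O)(=O)N1C(=O)c1ccccc1` carries a plain benzoyl group; in an assay on HEK-Blue hNOD1 cells for antagonist activity at Nucleotide-binding oligomerization domain-containing protein 1 (Homo sapiens), read by reporter gene assay, with stated times of 3 h and 20 h (a lower number here means a stronger inhibitor, a higher number a weaker inhibitor), compound 1 is recorded as "not determined" (no result reported). Within the data shown here, compound 2 `CCCCOC(=O)CC1c2cccc(C)c2S(=O)(=O)N1C(=O)c1ccc(C(F)(F)F)cc1` adds a trifluoromethyl group to that benzoyl ring, and in this assay compound 2 gives 1310 nM, the only number available, so compound 2 stands alone rather than anywhere in an order. Compound 3 `CCCCOC(=O)CC1c2cccc(C)c2S(=O)(=O)N1C(=O)c1cccc(C(F)(F)F)c1` differs from compound 2 only in 3-(trifluoromethyl)phenyl in place of 4-(trifluoromethyl)phenyl on a carbonyl carbon, the same atoms joined differently. Among the measured compounds shown here, no measured pair shows what such a shift does, so the expected step from compound 2 to compound 3 is a 1.1-fold higher number from compound 2 to compound 3 (0.06 log units; within the scatter), in either direction and likely not beyond the usual scatter. Compound 3 is therefore expected to give about 1500 nM in this assay, within a range from 500 nM to 5000 nM.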

Compound 3, half-maximal inhibitory concentration: 1050 nM
Compound 3: the middle estimate sits 1.4-fold (0.15 log units) above what was measured; measured number inside the range.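

Moving the trifluoromethyl group, so that 3-(trifluoromethyl)phenyl replaces 4-(trifluoromethyl)phenyl on the carbonyl carbon, gives a 1.2-fold lower number from compound 2 to compound 3 (0.10 log units; within the scatter) in this assay. Among these compounds, this is the first measured comparison at this position, and it shows that these two arrangements of the same atoms cannot be told apart in this assay. Nothing measured here offers an explanation for this result.

From the compounds shown here alone, with compound 1 recorded as "not determined" (no result reported), the step from the plain benzoyl group to either trifluoromethyl compound cannot be read, so what the trifluoromethyl group itself contributes remains unknown. Also open, going by these compounds, is how an amine or a carboxylic acid on the same benzoyl ring, or a methyl ester in place of the butyl ester, would read in this assay.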